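This account rests on a few compounds, and the source may have more. Where it says the series, first, only, none or still open, it means among the compounds named here.

The measured compounds in this series:

compound 1 `Fc1ccc(Nc2nc(-c3cccc(F)c3)nc3ccc(F)cc23)cc1` — > 50000 nM
compound 2 `Fc1cccc(Nc2nc(-c3cccc(F)c3)nc3ccc(F)cc23)c1` — 47600 nM
compound 3 `Fc1cccc(-c2nc(Nc3ccccc3Cl)c3cc(F)ccc3n2)c1` — > 50000 nM

All three share one core and differ only in the ring carried on the nitrogen. In a functional assay on MDA-MB-231 cells (Homo sapiens) for cytotoxicity, read by MTT assay, with a stated time of 48 h (on this read-out higher numbers stand for weaker inhibition and lower numbers for stronger inhibition), compound 3 reaches only the limit of the assay and gives no number, a limit shared with compound 1 (the limit of > 50000 nM in this assay, at which 2 of the 3 values shown sit). Among the compounds with values here, compound 2 is the one compound with a numerical value, and even that value sits very close to the limit; the step of an at least 1.0-fold lower number from compound 1 to compound 2 (0.02 log units; that floor lies within the scatter) lies within the scatter, as does an at least 1.0-fold higher number from compound 2 to compound 3 (0.02 log units; that floor lies within the scatter), while a step that the two limits leave unreadable from compound 1 to compound 3 cannot be read at all.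

Compound 4 `Oc1ccccc1Nc1nc(-c2cccc(F)c2)nc2ccc(F)cc12` takes the step (hydroxy in place of chloro on an aromatic carbon). No measured step in the set touches a hydroxy group; the three steps shown only exchange one halogen-bearing ring for another, and none of them moves a value beyond the scatter. There is therefore no measured ground for expecting a readable shift in this assay, and the estimate for compound 4 is that it stays near the limit, with a number no higher from compound 3 to compound 4 (the limit leaves the size open) taken as no step beyond the scatter. Compound 4 is thus expected to give about 50000 nM, within a range from 15000 nM to 150000 nM.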

Compound 4, half-maximal inhibitory concentration: > 50000 nM
Compound 4 ended at the assay's limit; the forecaster's own chance of this, stated with the estimate: 60%; the middle value sits exactly at the limit.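

Exchanging chloro for hydroxy on this aromatic carbon, ortho to a large group, gives the one ring in the set that carries no halogen, and in this assay compound 4 gives > 50000 nM, which is a limit of the assay and not a number. So bringing in a hydrogen-bond donor and a hydrogen-bond acceptor at this place does not yield a value clear of the limit, and the only step that can be read is an at least 1.0-fold higher number from compound 2 to compound 4 (0.02 log units; that floor lies within the scatter). The steps to compound 4 from compound 3 and from compound 1 cannot be read because both ends of each are limits: the limit of > 50000 nM in this assay, at which 3 of the 4 values shown sit.

The compounds shown leave open whether any other group at this place, such as an amine, a methoxy group or a carboxylic acid, would give a value clearly away from the limit. They also leave open how far compound 1, compound 3 and compound 4 differ from one another, since none of the three has a number in this assay.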